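This account rests on a few compounds, and the source may have more. Where it says the series, first, only, none or still open, it means among the compounds named here.

Compound 1, `N/C(=N\NC(=S)N1CCCCCC1)c1ccccn1`, was tested in a functional assay on HeLa cells (Homo sapiens) for cytotoxicity, read by MTT assay, with a stated time of 72 h, tested at 100 uM (a higher number here means more inhibition of growth at the concentration tested, a lower number less inhibition of growth), where compound 1 gives 88.7%. Compound 2, `N/C(=N\NC(=S)N1CCOCC1)c1ccccn1`, carries a different core; the difference between the two cores is not broken down here. In this assay, going by the values given here, compound 2 gives 87.2%, a value that sits within the scatter of the one for compound 1. Compound 3, `Cc1ccnc(/C(N)=N/NC(=S)N2CCOCC2)c1`, differs from compound 2 by a single change: methyl in place of hydrogen on an aromatic carbon In this assay compound 3 gives 82.7%, and the step of a number 4.5 percentage points lower from compound 2 to compound 3 (within the scatter) cannot be told apart from no change at all. Compound 4, `Cc1ccnc(/C(N)=N/NC(=S)N2CCCCCC2)c1`, has not yet been tested. Among the compounds with values here, its relation to compound 1 is described by methyl in place of hydrogen on an aromatic carbon, and this is the same change, at the same place, as the one seen between compound 2 and compound 3. Resting on the measured step of a number 4.5 percentage points lower from compound 2 to compound 3 (within the scatter), compound 4 is expected to show a step of a number 4.7 percentage points lower from compound 1 to compound 4 (within the scatter). Compound 4 is therefore estimated at 84% in this assay, with a likely range from 74% to 92%.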

Compound 4, percent growth inhibition at one concentration: 91.6%
Beside the measured number, compound 4's estimate is 7.6 percentage points below it; measured number inside the range.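

In this assay, methyl in place of hydrogen on an aromatic carbon, opposite the ring nitrogen, gives a number 2.9 percentage points higher from compound 1 to compound 4 (within the scatter), a step that cannot be told apart from no change. Set beside the step for the same change on the other core, it does not differ from it: the same change on two cores in this assay, a number 4.5 percentage points lower (within the scatter) from compound 2 to compound 3 and a number 2.9 percentage points higher (within the scatter) from compound 1 to compound 4, 7.4 percentage points apart, within the scatter of two such steps. Going by these compounds alone, this shows that, across these two pairs, the change can be carried from one core to the other without a step that rises out of the scatter, but it does not show that the two steps are truly alike in size or direction, or that the same would hold at another concentration, as each rests on a single concentration and there are only two pairs.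

The compounds shown leave open whether a chlorine atom, a methoxy group or an amine at this place would behave as methyl does. They also leave open whether a longer chain there would give a step beyond the scatter on either core.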